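The compounds below may be only part of what the source reports. "The series", "measured", "known", "first", "only" and "open" are said of these compounds alone.

Series measured in a functional assay on MCF7 cells (Homo sapiens) for inhibition, with a stated time of 48 h, tested at 50 uM; a higher number here means more inhibition of growth at the concentration tested, a lower number less inhibition of growth:

- compound 1 `C=C[C@@](C)(/C=C/c1ccc(OC(=O)CC)cc1)CCC=C(C)C`: 23%
- compound 2 `CC[C@](C)(CCCC(C)C)CCc1ccc(O)c(I)c1`: 40%
- compound 3 `COc1ccccc1/C=C/[C@@](C)(/C=C/c1ccc(O)cc1)CCC=C(C)C`: 42%

Compound 3 at 42% cannot be separated from compound 2 at 40%, as the two lie within the scatter of each other. Compound 1 at 23% lies lower than compound 3, and that gap is beyond the scatter.

The next compound to be tested is compound 4 `CC(C)=CCC[C@@](C)(/C=C/c1ccc(N)cc1)/C=C/c1ccc(O)cc1`. It departs from compound 3 in one place: 4-aminophenyl in place of 2-methoxyphenyl on a double-bonded chain carbon bound to a double-bonded chain carbon. A 4-aminophenyl stands in place of the 2-methoxyphenyl on a double-bonded chain carbon bound to a double-bonded chain carbon, and the rest of the structure is unchanged.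

Among the compounds with values here, no two measured compounds differ in only one place, so the series offers no measured step to guide this change, and its direction cannot be read from the data. With so little to go on, no step beyond the scatter is expected in this assay, although a small loss is slightly favoured. The estimated change is a number 4 percentage points lower from compound 3 to compound 4 (within the scatter), and the uncertainty around it is wide. For compound 4 the estimated value is 38%, with an expected range of 20% to 56%.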

Compound 4, percent growth inhibition at one concentration: 48%
Compound 4: middle estimate off by 10 percentage points, on the low side, within the range that was stated.
By their numbers in this assay, from the lowest: compound 1; then compounds 2, 3 and 4 (each within the scatter of the next).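

In this assay, within the data shown here, the step of a number 6 percentage points higher from compound 3 to compound 4 (within the scatter) is the first single change that can be read, and it concerns the group on a double-bonded chain carbon bound to a double-bonded chain carbon. At this place, 4-aminophenyl and 2-methoxyphenyl cannot be told apart, even though the exchange replaces a group with 0 hydrogen-bond donors by one with 1 hydrogen-bond donor and swaps oxygen for nitrogen in the substituent. No measurement available here explains this outcome or ties any property of either group to it.

The step changes the substituent and where it sits on the ring together, so the share of each in the result stays unresolved, and a single step within the scatter gives no measure of how much this place can affect growth inhibition. A plain phenyl or a phenyl carrying a carboxylic acid at this place would show whether the ring needs a substituent at all and whether a step beyond the scatter can arise here.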